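Methoxy on the core of compound 1

The compounds below may be only part of what the source reports. "The series", "measured", "known", "first", "only" and "open" are said of these compounds alone.

Values so far in a physicochemical assay for lipophilicity, using the shake flask method (on this read-out higher numbers stand for higher lipophilicity and lower numbers for lower lipophilicity), for the series
- compound 1 `CC(C)Oc1cc(Oc2ccc(S(C)(=O)=O)cc2)cc(-c2nccc(=O)[nH]2)c1` gives 2.14
- compound 2 `CC(C)Oc1cc(Oc2cnc(C(=O)N(C)C)nc2)cc(-c2nccc(=O)[nH]2)c1` gives 0.97
- compound 3 `CCS(=O)(=O)c1ccc(Oc2cc(O[C@@H](C)CO)cc(-c3nccc(=O)[nH]3)c2)cc1` gives 1.42

Compound 1 has the highest number of the three. Compound 3 and compound 2 both lie lower, each by more than the usual scatter of repeated measurements, and compound 2 is the furthest away.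

The next compound to be read is compound 4 `COc1cnc(-c2cc(Oc3ccc(S(C)(=O)=O)cc3)cc(OC(C)C)c2)[nH]c1=O` and it carries one change from compound 1 (methoxy in place of hydrogen on an aromatic carbon). Methoxy stands in place of hydrogen on an aromatic carbon of the six-membered aromatic ring with 2 nitrogen, ortho to a group of 1 heavy atom and para to a large group.

Among the compounds with values here, no two measured compounds differ in one place only, so the series gives no direct measure of this change. The estimate therefore starts from compound 1 at 2.14 as the nearest measured structure. In this assay the estimated step (a number 0.06 log units higher from compound 1 to compound 4 (within the scatter)) is expected to stay within the scatter, with no clear direction. Compound 4 is expected at 2.2 on this estimate, within a range of 1.85 to 2.55 in the same read-out.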

Compound 4, distribution coefficient: 2.21
Compound 4: the middle estimate sits 0.01 log units below what was measured, within the range that was stated.
By their numbers in this assay, from the lowest: compound 2; then compound 3; then compounds 1 and 4 (each within the scatter of the next).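

Within the data shown here, compound 4 forms the first pair that differs in one place only: in this assay, methoxy in place of hydrogen on an aromatic carbon gives a number 0.07 log units higher from compound 1 to compound 4 (within the scatter) and so shows no clear shift in either direction. Among these compounds, this places a first direct reading on this position, on an aromatic carbon of a six-membered aromatic ring with 2 nitrogen, ortho to a group of 1 heavy atom and two atoms from the ring nitrogen, which compound 1, compound 2 and compound 3 could not give, as each differs from the others in more than one place. No supporting measurement bears on the reason for this result.

The reading covers one group at this position on the core of compound 1, so an amine, a carboxylic acid or a longer chain in the same place remains an open question. Also open, on these data alone, is whether methoxy at this position would give a comparable step with the other substituents carried by compound 2 or compound 3.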